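Swapping one aryl group on a poorly tolerated compound

This account rests on a few compounds, and the source may have more. Where it says the series, first, only, none or still open, it means among the compounds named here.

- Compound 1 `O=C(Nc1cccc(-n2cc(-c3ccncc3)c(-c3ccc(Cl)c(O)c3)n2)c1)Nc1cccc(C(F)(F)F)c1` gives > 32500 nM (a limit)
- Compound 2 `COc1cc(-c2nn(-c3cccc(NC(=O)Nc4cc(C(F)(F)F)cc(C(F)(F)F)c4)c3)cc2-c2ccncc2)ccc1Cl` gives 4830 nM
- Compound 3 `COc1cc(-c2nn(-c3cccc(NC(=O)c4cccc(C(F)(F)F)c4)c3)cc2-c2ccncc2)ccc1Cl` gives > 50000 nM (a limit)

In a functional assay on HCT-116 cells (Homo sapiens) for inhibition, read by sulforhodamine B assay, with a stated time of 48 h (a lower number here means that less compound is tolerated, a higher number that more compound is tolerated), compound 1 reports only a limit (> 32500 nM) and not a number. Compound 3 likewise reports only a limit (> 50000 nM). Of the three, only compound 2 gives a true number (4830 nM).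

Compound 4 `O=C(Nc1cccc(-n2cc(-c3ccncc3)c(-c3ccc(Cl)c(O)c3)n2)c1)Nc1ccc(Cl)c(Cl)c1` shares the core of compound 1 and differs in one place. It carries 3,4-dichlorophenyl in place of 3-(trifluoromethyl)phenyl on an amide-type nitrogen.

Going by the values given here, no pair of measured compounds shows this swap, so any forecast is loose. A modest shift in this assay toward less compound being tolerated is the expectation, though compound 4 could also end up reporting only a limit. The number from compound 2 (4830 nM) suggests how far down the estimate should reach. The expected step of an at least 1.6-fold lower number from compound 1 to compound 4 (0.21 log units; that floor lies within the scatter) is therefore small and uncertain. For compound 4 the estimated value is 20000 nM, with an expected range from 6000 nM to 50000 nM.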

Compound 4, concentration lethal to 50% of the cells: > 32500 nM
Compound 4 gave a limit, no number; the forecaster's own chance of this, stated with the estimate: 45%; middle value at least 1.6-fold (0.21 log units) from the limit.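

Compound 1 and compound 4 both report only a limit and not a number, so the step between them cannot be read. As far as these compounds go, it remains open whether 3,4-dichlorophenyl in place of 3-(trifluoromethyl)phenyl on an amide-type nitrogen shifts the read-out at all, and in which direction.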